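This account rests on a few compounds, and the source may have more. Where it says the series, first, only, none or still open, it means among the compounds named here.

Compound 1 `CCc1ccc(SCc2ccc(/C=C/C(=O)Nc3ccccc3N)cc2)cc1`: 19.5%
Compound 2 `Nc1ccccc1NC(=O)c1ccc(CSc2ccc(C(F)(F)F)cn2)cc1`: 7.57%
Compound 3 `COc1ccc(SCc2ccc(C(=O)Nc3ccccc3N)cc2)cc1OC`: 78.9%

All three values come from a functional assay on SMMC-7721 cells (Homo sapiens) for inhibition, read by CCK-8 assay, with a stated time of 72 h, tested at 8 uM; on this read-out lower numbers stand for less inhibition of growth and higher numbers for more inhibition of growth at the one concentration tested. Compound 1 stands second highest of the three numbers. Compound 2 lies lower and compound 3 higher, and both gaps to compound 1 are beyond the usual scatter. Compound 4 `CC(C)(C)c1ccc(SCc2ccc(/C=C/C(=O)Nc3ccccc3N)cc2)cc1` has not been measured yet. It has tert-butyl in place of ethyl on an aromatic carbon, para to a large group (tert-butyl in place of ethyl on an aromatic carbon). For the measured compounds named here, no measured pair here differs in just one place, so the data do not show how much such a change matters. The closest guide is compound 1 at 19.5% and no step beyond the scatter is expected. The estimated change is a number 2.5 percentage points higher from compound 1 to compound 4 (within the scatter) and would be a small rise if it appears at all. For compound 4 the expected value is 22% with an estimated range from 5% to 48%.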

Compound 4, percent growth inhibition at one concentration: 23.6%
Compound 4: the middle estimate sits 1.6 percentage points below what was measured; measured number inside the range.
By their numbers in this assay, from the lowest: compound 2; then compounds 1 and 4 (each within the scatter of the next); then compound 3.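

In this assay, tert-butyl in place of ethyl on this aromatic carbon gives a number 4.1 percentage points higher from compound 1 to compound 4 (within the scatter). For the compounds shown here, this is the first pair here that differs in just one place, and it shows that two extra carbons at this position, para to a large group, do not shift growth inhibition beyond the usual scatter. Nothing measured here explains this result.

Both groups contain only carbon and hydrogen, so this pair says nothing about an amine or a carboxylic acid on the same carbon. From the compounds shown here alone, whether either would shift growth inhibition beyond the scatter remains open.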